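Swapping One Ring for Another on a Shared Core

A few compounds are considered here, and "the series" means these few. Any claim that something is new, unique, unknown or untested is made for them only; others in the source may bear on it.

Going by the values given here, compound 1 `Cc1ccc(C(Nc2ccc(C(=O)O)cc2)c2ccc3cccnc3c2O)cc1` is the only compound here with a number in hand. In an assay on isolated protein for inhibition of CAAX prenyl protease 2 (Homo sapiens), with stated times of 60 s and 60 min (a lower number here means a stronger inhibitor, a higher number a weaker inhibitor), compound 1 gives 7100 nM, which places it among the weaker inhibitors in that test. Compound 2 `CCOC(=O)c1ccc(NC(c2ccc(Cl)cc2)c2ccc3cccnc3c2O)cc1` shares the same core, but in this assay compound 2 gives "not determined" (no result reported), so it adds nothing to compare against. Compound 3 `O=C(O)c1ccc(NC(c2cccnc2)c2ccc3cccnc3c2O)cc1` has not been measured yet. Set beside compound 1, the change is pyridin-3-yl in place of 4-methylphenyl on a saturated chain carbon bound to an aromatic carbon and a nitrogen on an aromatic ring. Among the compounds with values here, no step between two measured compounds is available, so the data say nothing about how this assay responds to a change of this kind, and the expectation rests on compound 1 alone. The step of a 1.4-fold higher number from compound 1 to compound 3 (0.15 log units; within the scatter) is expected to be small, leaning toward a slightly weaker inhibitor, and it may well stay within the usual scatter. With that, compound 3 is expected to give about 10000 nM in this assay, with a plausible range from 3000 nM to 40000 nM, and a real chance that only a limit is reported.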

Compound 3, half-maximal inhibitory concentration: 14000 nM
For compound 3 the middle estimate is 1.4-fold (0.15 log units) below the measured one; the measured number falls inside the stated range.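

At the saturated chain carbon bound to an aromatic carbon and a nitrogen on an aromatic ring, pyridin-3-yl in place of 4-methylphenyl gives a 2.0-fold higher number from compound 1 to compound 3 (0.29 log units; within the scatter) in this assay. Going by these compounds alone, this is the first direct reading of a change at this position, and it shows that a six-membered aromatic ring of carbon only and one with 1 hetero atom and 1 hydrogen-bond acceptor cannot be told apart in this test, even though the swap also removes the methyl group's carbon from the count of heavy atoms. No supporting measurement bears on this result, so the pair can record the outcome of the swap but cannot account for it.

A single pair cannot show how far this position's tolerance extends, since both groups compared here are six-membered aromatic rings. From the compounds shown here alone, whether a ring carrying an amine, or a longer chain with no ring at all, would also leave the reading within the scatter of compound 1 remains open.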